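Replacing the carbamoyl group of compound 2

The source may report more compounds than this note shows. Statements on the series, on what has been measured and on what is new or still open speak of the compounds shown alone.

Of the compounds shown here, three have been tested in an ADME assay on HEK-293T cells (Homo sapiens) for cytotoxicity, read by CCK-8 assay, with a stated time of 48 h (a higher number here means a weaker inhibitor, a lower number a stronger inhibitor), and none of them has given a number. Compound 1 (`COc1ccc(Oc2ccccc2-c2ccsc2S(=O)(=O)N2CCN(C(=S)Nc3ccc([N+](=O)[O-])cc3)CC2)cc1OC`) reached only a limit (> 20000 nM). Compound 2 (`COc1ccc(NC(=O)NCCNS(=O)(=O)c2ccc(-c3ccccc3OCc3ccccc3)s2)cc1`) also gave only a limit (> 50000 nM). Compound 3 (`O=S(=O)(NCCNC(=S)Nc1cc(C(F)(F)F)cc(C(F)(F)F)c1)c1ccc(-c2ccccc2O[C@H]2CC[C@@H](O)CC2)s1`) likewise stands at a limit (> 20000 nM). So compound 2 has no exact position among them. Compound 4 (`O=S(=O)(NCCNC(=S)Nc1ccc(Cl)cc1)c1ccc(-c2ccccc2OCc2ccccc2)s1`) departs from compound 2 on an amine nitrogen, where the (4-methoxyphenyl)carbamoyl group gives way to a group with no common name: a group of 10 heavy atoms (7 carbon, 1 nitrogen, 1 sulfur, 1 chlorine; one six-membered aromatic ring of carbon only) in place of a group of 11 heavy atoms (8 carbon, 1 nitrogen, 2 oxygen; one six-membered aromatic ring of carbon only), on an amine nitrogen. Within the data shown here, no measured pair shows what such a change does in this assay, so only a modest move toward a lower number is expected, an estimated at least 1.6-fold lower number from compound 2 to compound 4 (0.22 log units; that floor lies within the scatter). For compound 4 the expected value is 30000 nM (estimated range 10000 nM to 60000 nM).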

Compound 4, half-maximal inhibitory concentration: 12100 nM
The estimate for compound 4 lay 2.5-fold (0.39 log units) above the measured number; the measured number falls inside the stated range.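

In this assay, among these compounds, the change on the amine nitrogen gives the first exact number in this set and a readable direction: an at least 4.1-fold lower number from compound 2 to compound 4 (0.61 log units; beyond the scatter). As far as these compounds go, compound 2 stands at a limit, > 50000 nM, so the true size of this step remains unknown. The other two compounds offer no exact number for comparison: the limit of > 20000 nM in this assay, at which 2 of the 4 values shown sit.

The entering group differs from the (4-methoxyphenyl)carbamoyl group in both its sulfur and its chlorine, and the compounds shown do not separate these two changes. They also leave open what a carboxylic acid or a longer chain on this amine nitrogen would do.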